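Alkyne ring replacement: pyridin-3-yl for 4-chlorophenyl

This account rests on a few compounds, and the source may have more. Where it says the series, first, only, none or still open, it means among the compounds named here.

In an assay on HEK293 cells for displacement of a labelled ligand from metabotropic glutamate receptor 5 (Homo sapiens), with a stated time of 2 h (a lower number here means a stronger inhibitor, a higher number a weaker inhibitor), compound 2 `CN1CCc2nc(C#Cc3ccc(Cl)cc3)ccc2C1=O` gives 6150 nM, the highest of the two numbers seen; compound 1 `CN1CCc2nc(C#Cc3cccc(Cl)c3)ccc2C1=O` gives 250 nM. Going by the values given here, the one measured step, a 25-fold higher number from compound 1 to compound 2 (1.39 log units; beyond the scatter), shows that the ring on the triple-bonded carbon matters strongly. Compound 3 `CN1CCc2nc(C#Cc3cccnc3)ccc2C1=O` carries pyridin-3-yl in place of 4-chlorophenyl on a triple-bonded carbon. Among the compounds with values here, no measured step tests a ring with a hetero atom, so the step in this assay is expected from the size of the ring effect alone. Compound 3 is expected near 600 nM (range 120 nM to 3000 nM), a step of a 10-fold lower number from compound 2 to compound 3 (1.01 log units; beyond the scatter) that is expected to lower the number.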

Compound 3, inhibition constant: 27400 nM
Compound 3: middle estimate off by 46-fold (1.66 log units), on the low side; the measured number lies above the stated range.
By their numbers in this assay, from the lowest: compound 1; then compound 2; then compound 3.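

In this assay, pyridin-3-yl on the triple-bonded carbon gives a higher number than either chlorophenyl ring: a 4.5-fold higher number from compound 2 to compound 3 (0.65 log units; beyond the scatter), and a 110-fold higher number from compound 1 to compound 3 (2.04 log units; beyond the scatter). This position therefore responds not only to where the chlorine sits but also to the ring exchange, and the one ring with a hetero atom shown here does not match either chlorophenyl compound. No measured evidence explains this rise. From the compounds shown here alone, it remains open what an unsubstituted phenyl ring would give at this place, or a fluoro, methyl or methoxy group in place of the chlorine.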